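A few compounds are considered here, and "the series" means these few. Any claim that something is new, unique, unknown or untested is made for them only; others in the source may bear on it.

Compound 1 `CC(C)(C)c1cc(NC(=O)Nc2ccc(-c3cn4ccccc4n3)cc2)no1` holds the lowest number of the three measured compounds in a functional assay on MV4-11 cells (Homo sapiens) for cytotoxicity, read by MTT assay, with a stated time of 72 h; on this read-out higher numbers stand for weaker inhibition and lower numbers for stronger inhibition; compound 1 gives 3.09 nM. Compound 4 `CC(C)(C)c1cc(NC(=O)Nc2ccc(-c3cn4c(Cl)cccc4n3)cc2)no1` differs from it by chloro in place of hydrogen on an aromatic carbon, the new group sitting next to the ring nitrogen, ortho to a fused ring. For the measured compounds named here, two measured steps bear on this: compound 2 `CC(C)(C)c1cc(NC(=O)Nc2ccc(-c3cn4cc(I)ccc4n3)cc2)no1` gives 98.6 nM, a step of a 32-fold higher number from compound 1 to compound 2 (1.50 log units; beyond the scatter), and compound 3 `CC(C)(C)c1cc(NC(=O)Nc2ccc(-c3cn4cc(C5CC5)ccc4n3)cc2)no1` gives 15.8 nM, a step of a 5.1-fold higher number from compound 1 to compound 3 (0.71 log units; beyond the scatter). Both additions to the same ring raised the number, though at a different position. A rise beyond the scatter is therefore expected for compound 4, estimated as a 6.5-fold higher number from compound 1 to compound 4 (0.81 log units; beyond the scatter). Compound 4 is estimated at 20 nM, within a range from 5 nM to 80 nM.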

Compound 4, half-maximal inhibitory concentration: 56.1 nM
Estimate against measurement, compound 4: 2.8-fold (0.45 log units) below; the range from low to high includes it.
By their numbers in this assay, from the lowest: compound 1; then compound 3; then compounds 4 and 2 (each within the scatter of the next).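

Placing chloro next to the ring nitrogen gives a large step, an 18-fold higher number from compound 1 to compound 4 (1.26 log units; beyond the scatter), so this position also tolerates an addition poorly, even though the new group has only 1 heavy atom. Hydrogen therefore remains the group with the lowest number among the compounds shown. Nothing available explains this rise. The compounds shown leave open whether a fluoro, methoxy or amine group at this same position would give a similar step. They also leave open how chloro would behave at the position carrying iodo in compound 2.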